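Solubility notes on the shared core: compound 3 to compound 4

A few compounds are considered here, and "the series" means these few. Any claim that something is new, unique, unknown or untested is made for them only; others in the source may bear on it.

Measured so far in a physicochemical assay for solubility, read by HPLC, with a stated time of 24 h; on this read-out higher numbers stand for higher solubility and lower numbers for lower solubility:
compound 1 `CN(CCC#N)C[C@H]1CN(c2ccc(-n3cc(-c4ccccn4)cn3)c(F)c2)C(=O)O1` gives 64500 nM
compound 2 `O=C1O[C@@H](CN2CCCCC2)CN1c1ccc(-n2cc(-c3ccccn3)cn2)c(F)c1` gives 219000 nM
compound 3 `O=C1O[C@@H](Cn2ccnc2)CN1c1ccc(-n2cc(-c3ccccn3)cn2)c(F)c1` gives 12300 nM

Compound 3 stands lowest of the three in this assay: the two steps onto it are a 5.2-fold lower number from compound 1 to compound 3 (0.72 log units; beyond the scatter) and an 18-fold lower number from compound 2 to compound 3 (1.25 log units; beyond the scatter), while a 3.4-fold higher number from compound 1 to compound 2 (0.53 log units; beyond the scatter) separates the other pair. Compound 4 `O=C(NC[C@H]1CN(c2ccc(-n3cc(-c4ccccn4)cn3)c(F)c2)C(=O)O1)C(F)F` differs from compound 3 by ((difluoromethyl)carbonyl)amino in place of 1H-imidazol-1-yl on a saturated chain carbon bound to a saturated ring carbon. Among the measured compounds shown here, no measured step swaps the 1H-imidazol-1-yl for a group without a ring, so the two steps onto compound 3 bear only loosely; both show the 1H-imidazol-1-yl compound as the low point. For compound 4 a modest rise is therefore expected, a 2.0-fold higher number from compound 3 to compound 4 (0.31 log units; beyond the scatter), with wide uncertainty. Compound 4 is estimated at 25000 nM, between 7000 nM and 90000 nM.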

Compound 4, solubility: 29900 nM
The estimate for compound 4 lay 1.2-fold (0.08 log units) below the measured number; low and high end bracket the measured number.
By their numbers in this assay, from the lowest: compound 3; then compound 4; then compound 1; then compound 2.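

In this assay, among the compounds shown here, ((difluoromethyl)carbonyl)amino, the first group at this place to bring a carbonyl and an amide hydrogen, falls inside the range set by the three earlier groups: it gives a 2.4-fold higher number from compound 3 to compound 4 (0.39 log units; beyond the scatter) but also a 2.2-fold lower number from compound 1 to compound 4 (0.33 log units; beyond the scatter) and a 7.3-fold lower number from compound 2 to compound 4 (0.86 log units; beyond the scatter) as further steps down. The amide hydrogen therefore does not, by itself, bring the number up to those of the piperidin-1-yl and (2-cyanoethyl)(methyl)amino compounds. No supporting data explain this order.

Whether the difluoromethyl matters remains open, since the plain acetyl amide is not among the compounds shown. As far as these compounds go, a carboxylic acid or primary amine on the same saturated chain carbon also remains untested here.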